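Removing the Halogen from Compound 2

The compounds below may be only part of what the source reports. "The series", "measured", "known", "first", "only" and "open" are said of these compounds alone.

Compound 2 `Fc1cccc2c1CC2CN1CCN(c2cccc3c2OCCO3)CC1` was tested in a functional assay on the whole organism for antagonist activity, with Rattus norvegicus as the target (on this read-out lower numbers stand for an effect already at smaller amounts and higher numbers for an effect only at larger amounts of compound), where compound 2 gives 0.63 mg/kg. Compound 1 `Clc1cccc2c1CC2CN1CCN(c2cccc3c2OCCO3)CC1` gives 0.63 mg/kg, and compound 3 `COc1cc2c(cc1OC)C(CCN1CCN(c3cccc4c3OCCO4)CC1)C2` gives 1.25 mg/kg. Compound 2 thus stands level with compound 1, the two together holding the lowest of the three numbers, while compound 3 lies within the scatter of compound 2. For the measured compounds named here, the only measured step that bears on the question is no change at the digits printed from compound 1 to compound 2 (within the scatter), which left the number unchanged. Compound 4 `c1ccc2c(c1)CC2CN1CCN(c2cccc3c2OCCO3)CC1` differs from compound 2 by hydrogen in place of fluoro on an aromatic carbon. Going by the values given here, no measured step removes the halogen altogether, so the unchanged halogen swap is the sole guide. The step is therefore expected to stay within the scatter, no change at the digits printed from compound 2 to compound 4 (within the scatter), and compound 4 is estimated at 0.63 mg/kg, between 0.31 mg/kg and 1.25 mg/kg.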

Compound 4, minimum effective dose: 0.63 mg/kg
Compound 4: middle estimate and measured number agree at the digits printed, and the stated range covers the measured number.
By their numbers in this assay, from the lowest: compounds 1, 2, 4 and 3 (each within the scatter of the next).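

In this assay, hydrogen in place of fluoro on an aromatic carbon brings no change at the digits printed from compound 2 to compound 4 (within the scatter), and hydrogen in place of chloro at the same carbon brings no change at the digits printed from compound 1 to compound 4 (within the scatter). The earlier step only exchanged one halogen for another, whereas these steps show that, across compounds 1, 2 and 4, the number does not depend on a halogen being present at this position. Nothing available gives a reason for this result.

As far as these compounds go, whether this position would tolerate an amine or a carboxylic acid remains open. So does whether other carbons of this aromatic ring would behave the same way.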